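The source may hold more compounds than are shown below. What is called first, only, known or untested is meant among the compounds shown, and "the series" means these compounds.

Measured so far:
Compound 1, `COc1cc(-c2nn(-c3cccc(NC(=O)c4cccc(C(F)(F)F)c4)c3)cc2-c2ccncc2)ccc1Cl`, gives 1560 nM in a functional assay on SK-MEL-2 cells (Homo sapiens) for inhibition, read by sulforhodamine B assay, with a stated time of 48 h; a lower number here means a stronger inhibitor of growth, a higher number a weaker inhibitor of growth.
Compound 2, `COc1cc(-c2nn(-c3cccc(NC(=O)Nc4ccc(Cl)c(Cl)c4)c3)cc2-c2ccncc2)ccc1Cl`, gives 1140 nM in this assay.
Compound 3, `COc1cc(-c2nn(-c3cccc(NC(=O)Nc4cccc(C(F)(F)F)c4)c3)cc2-c2ccncc2)ccc1Cl`, gives 970 nM in this assay.

Compound 3 shows the lowest of the three numbers, but its gap to compound 2 and its gap to compound 1 both fall within the scatter, so the three compounds cannot be ordered on these data. Compound 4, `COc1cc(-c2nn(-c3cccc(NC(=O)c4ccc(Cl)c(C(F)(F)F)c4)c3)cc2-c2ccncc2)ccc1Cl`, has not yet been measured in this assay. It differs from compound 3 in one place: 4-chloro-3-(trifluoromethyl)phenyl in place of (3-(trifluoromethyl)phenyl)amino on a carbonyl carbon. This change is essentially the reverse of the step from compound 1 to compound 3, with a chlorine added to the aryl group. The step that bears most directly on it is a 1.6-fold lower number from compound 1 to compound 3 (0.21 log units; within the scatter). The step of a 1.4-fold lower number from compound 1 to compound 2 (0.14 log units; within the scatter) likewise stayed within the scatter, and the step of a 1.2-fold lower number from compound 2 to compound 3 (0.07 log units; within the scatter) shows that exchanging one aryl group for another on the amide-type nitrogen moved nothing beyond the scatter either. Nothing measured here points to a step beyond the scatter in either direction. Compound 4 is therefore expected to land close to compound 3. The estimated step is a 1.3-fold higher number from compound 3 to compound 4 (0.13 log units; within the scatter). The estimate for compound 4 is 1300 nM, with a range from 600 nM to 2800 nM.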

Compound 4, concentration for 50% growth inhibition: 1900 nM
Compound 4: the middle estimate sits 1.5-fold (0.16 log units) below what was measured; low and high end bracket the measured number.
By their numbers in this assay, from the lowest: compounds 3, 2, 1 and 4 (each within the scatter of the next).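

Compound 4 takes away the amide-type nitrogen on the carbonyl carbon, and with it the hydrogen-bond donor counted for the leaving group, yet in this assay the exchange gives a 2.0-fold higher number from compound 3 to compound 4 (0.29 log units; within the scatter) and, against the dichlorinated urea, a 1.7-fold higher number from compound 2 to compound 4 (0.22 log units; within the scatter) and so neither step leaves the scatter. For the compounds shown here, the same holds for the first change on the aryl ring of the benzamide itself, where chloro in place of hydrogen on an aromatic carbon gives a 1.2-fold higher number from compound 1 to compound 4 (0.09 log units; within the scatter) and thus adds nothing that can be told from the scatter. At this place, then, both urea and amide linkages and an added chloro group on the aryl ring are tolerated to the same degree in these four compounds, and no information on hand explains this flat result.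

From the compounds shown here alone, all four compounds carry an aryl group reached through the carbonyl carbon, so it stays open whether a saturated amine such as piperidine or a short alkyl chain at this place would produce a step beyond the scatter. Going by these compounds, it also stays open whether a carboxylic acid or a methoxy group on that aryl ring would do so.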